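Phenoxy ring variation in the shared-core series

The compounds below may be only part of what the source reports. "The series", "measured", "known", "first", "only" and "open" are said of these compounds alone.

Measured compounds and values in a functional assay on SMMC-7721 cells (Homo sapiens) for antiproliferative activity, read by MTT assay, with a stated time of 72 h; on this read-out higher numbers stand for weaker inhibition and lower numbers for stronger inhibition:
compound 1 `Cc1nn(C)c(Oc2cccc(F)c2)c1/C=N\CCCCCCOc1cc2oc(=O)cc(C)c2cc1Cl`: 23600 nM
compound 2 `Cc1nn(C)c(Oc2cccc(F)c2F)c1/C=N\CCCCCCOc1cc2oc(=O)cc(C)c2cc1Cl`: 22800 nM
compound 3 `Cc1nn(C)c(Oc2ccc(F)c(F)c2)c1/C=N\CCCCCCOc1cc2oc(=O)cc(C)c2cc1Cl`: only a limit is reported, > 25000 nM

The three measured compounds differ only in the fluorine pattern of the phenoxy ring on the shared core. Compound 1 to compound 2 gives a 1.0-fold lower number from compound 1 to compound 2 (0.01 log units; within the scatter), compound 1 to compound 3 gives an at least 1.0-fold higher number from compound 1 to compound 3 (0.02 log units; that floor lies within the scatter), and compound 2 to compound 3 gives an at least 1.0-fold higher number from compound 2 to compound 3 (0.04 log units; that floor lies within the scatter). Compound 3 stands at the limit of > 25000 nM in this assay, at which 1 of the 3 values shown sits, so its place relative to compound 1 and compound 2 is known only as a floor, and that floor lies within the scatter of both.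

The next compound, compound 4 `Cc1nn(C)c(Oc2ccc(Cl)cc2)c1/C=N\CCCCCCOc1cc2oc(=O)cc(C)c2cc1Cl`, carries the change (4-chlorophenyl in place of 3,4-difluorophenyl on an oxygen on an aromatic ring). Among the measured compounds shown here, the steps that bear on it are the phenoxy ring changes above, all within the scatter, and none of them brings a chlorine onto that ring. On this basis no step beyond the scatter is expected in this assay from compound 3 to compound 4, with the caveat that compound 3 itself is only a limit. Compound 4 is therefore estimated at 25000 nM, within 12000 nM to 50000 nM, and the expected step is a number no higher from compound 3 to compound 4 (the limit leaves the size open).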

Compound 4, half-maximal inhibitory concentration: 2080 nM
The estimate for compound 4 lay 12-fold (1.08 log units) above the measured number; the whole stated range lies above it.
By their numbers in this assay, from the lowest: compound 4; then compounds 2 and 1 (each within the scatter of the next). At a limit, above all of these: compound 3.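

In this assay, the position on an oxygen on an aromatic ring had shown no step beyond the scatter across the fluorine patterns, but it does respond to 4-chlorophenyl: an 11-fold lower number from compound 1 to compound 4 (1.05 log units; beyond the scatter), and an 11-fold lower number from compound 2 to compound 4 (1.04 log units; beyond the scatter). Compound 3 carries only a limit, so the step of an at least 12-fold lower number from compound 3 to compound 4 (1.07 log units; beyond the scatter) gives a floor and not a size: the limit of > 25000 nM in this assay, at which 1 of the 4 values shown sits. The series therefore shows that this position can move the read-out by a large margin, and that the fluorine patterns in compounds 1, 2 and 3 did not reveal this sensitivity.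

Each step to compound 4 changes both the halogen and the substitution pattern, so the shown compounds cannot separate the contribution of chlorine from that of its place on the ring, and nothing measured here explains the gain. Among the compounds shown here, also open is whether an unsubstituted phenyl, a bromophenyl or a methylphenyl on the same oxygen would match compound 4, and whether the gain would persist with a different chain in place of the one shared by these compounds.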